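This account rests on a few compounds, and the source may have more. Where it says the series, first, only, none or still open, it means among the compounds named here.

Compound 1 `CCC(Oc1ccc(-n2cc(C(F)(F)F)cn2)cc1)c1ccc(C(=O)NCCC(=O)O)cc1`: in an ADME assay on microsomes from liver (Homo sapiens) for metabolic stability (a higher number here means faster removal of the compound, a lower number slower removal), compound 1 gives a limit of < 8 mL/min/kg, not a number.
Compound 2 `CCCC(Oc1ccc(-n2cc(C(F)(F)F)cn2)cc1)c1ccc(C(=O)NCCC(=O)O)cc1`: in this assay compound 2 gives 16 mL/min/kg.

For the measured compounds named here, compound 2 holds the only numerical value shown; the other value is a limit, so its standing cannot be ranked beyond that. Going by the values given here, the one measured step is an at least 2.0-fold higher number from compound 1 to compound 2 (0.30 log units; that floor lies within the scatter), and compound 1 sits at the limit of < 8 mL/min/kg in this assay, at which 1 of the 2 values shown sits, which leaves the true size of that step open.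

Compound 3 `CC(C)(C)C(Oc1ccc(-n2cc(C(F)(F)F)cn2)cc1)c1ccc(C(=O)NCCC(=O)O)cc1` differs from compound 2 by tert-butyl in place of propyl on a saturated chain carbon bound to an aromatic carbon and an oxygen on an aromatic ring. Among the compounds with values here, the earlier step also lengthened the same saturated chain, so it is the only guide here. Since that step was only just at the edge of the scatter, and the present change adds one carbon while branching the chain, a small upward drift is expected, not clearly beyond the scatter: a 1.4-fold higher number from compound 2 to compound 3 (0.14 log units; within the scatter). Compound 3 is therefore estimated at 22 mL/min/kg, within 10 mL/min/kg to 45 mL/min/kg.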

Compound 3, clearance: 31 mL/min/kg
The estimate for compound 3 lay 1.4-fold (0.15 log units) below the measured number; the range from low to high includes it.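

Tert-butyl in place of propyl on the saturated chain carbon bound to an aromatic carbon and an oxygen on an aromatic ring gives a 1.9-fold higher number from compound 2 to compound 3 (0.29 log units; within the scatter), so this change alone cannot be told apart from repeat-measurement noise in this assay. Tert-butyl in place of ethyl at the same carbon gives an at least 3.8-fold higher number from compound 1 to compound 3 (0.58 log units; beyond the scatter), the first step shown that clears the scatter, so the group at this position does register when the ethyl and tert-butyl compounds are compared. Compound 1 gives a limit, not a number, so this step has only a floor and its true size stays unknown: the limit of < 8 mL/min/kg in this assay, at which 1 of the 3 values shown sits.

On these data alone, how a straight butyl chain or a cyclopropyl ring would read at this carbon remains open. Until then, the effects of chain length and branching cannot be separated.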